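Swapping a Side Chain on a Saturated Ring Carbon

The source may hold more compounds than are shown below. What is called first, only, known or untested is meant among the compounds shown, and "the series" means these compounds.

Measured so far:
compound 1 `COCCOC1CCN(c2ccc(-c3cc(-c4cccc(Br)c4)c4c(N)ncnc4n3)nn2)CC1`: 10 umol/kg
compound 2 `Nc1ncnc2nc(-c3ccc(N4CCC(=NOC5CCOCC5)CC4)nn3)cc(-c3cccc(Br)c3)c12`: 7 umol/kg

Of the compounds shown here, two sharing the same core have been tested in a functional assay; on this read-out lower numbers stand for an effect already at smaller amounts and higher numbers for an effect only at larger amounts of compound. Compound 1 gives 10 umol/kg, while compound 2 gives 7 umol/kg. Compound 1 stands at the higher of the two numbers, but the distance to compound 2 lies within the usual scatter, so neither can be called stronger.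

Compound 3 `Nc1ncnc2nc(-c3ccc(N4CCC(COC5CCOCC5)CC4)nn3)cc(-c3cccc(Br)c3)c12` has not been measured. It differs from compound 1 in one place: ((oxan-4-yl)oxy)methyl in place of 2-methoxyethoxy on a saturated ring carbon. Within the data shown here, no measured pair isolates this change, so the direction of the step is open. The incoming group carries the same six-membered oxygen ring that compound 2 bears, and compound 2 gives 7 umol/kg, a number close to compound 1. The expected step is a 1.3-fold lower number from compound 1 to compound 3 (0.10 log units; within the scatter), not beyond the scatter. Compound 3 is estimated at 8 umol/kg, within a range from 3 umol/kg to 25 umol/kg.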

Compound 3, dose for half-maximal effect: 5 umol/kg
For compound 3 the middle estimate is 1.6-fold (0.20 log units) above the measured one; measured number inside the range.
By their numbers in this assay, from the lowest: compounds 3, 2 and 1 (each within the scatter of the next).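

In this assay, replacing 2-methoxyethoxy with ((oxan-4-yl)oxy)methyl on this saturated ring carbon gives a 2.0-fold lower number from compound 1 to compound 3 (0.30 log units; within the scatter). The incoming group has 8 heavy atoms and a six-membered ring, whereas the outgoing group has 5 heavy atoms and no ring, yet the two compounds cannot be told apart on this read-out. So this position accepts a larger, ring-bearing side chain with the same count of hydrogen-bond acceptors and no change beyond the scatter, but nothing available explains this result.

The compounds shown all carry neutral side chains containing oxygen, so it remains open how an amine or a carboxylic acid at this carbon would read out. From the compounds shown here alone, it is also open whether the ring oxygen matters, which a cyclohexyl ring in place of the oxan-4-yl ring would test.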